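A few compounds are considered here, and "the series" means these few. Any claim that something is new, unique, unknown or untested is made for them only; others in the source may bear on it.

In a functional assay on HT-29 cells (Homo sapiens) for inhibition, read by sulforhodamine B assay, with a stated time of 48 h (on this read-out higher numbers stand for weaker inhibition of growth and lower numbers for stronger inhibition of growth), compound 1 `c1ccc(-c2ccc(NC3=NCCO3)cc2)cc1` gives 5800 nM. Compound 2 `c1cc(NC2=NCCO2)cc(OC2CCCCCC2)c1` gives 6900 nM, which lies within the usual scatter of compound 1. Compound 3 `c1ccc(COc2cccc(NC3=NCCO3)c2)cc1` gives 800 nM, a lower number than that of compound 1 and beyond the scatter, meaning stronger inhibition of growth. Compound 1 therefore stands with compound 2, well apart from compound 3. Compound 4 `CC(C)(C)c1ccc(NC2=NCCO2)cc1` differs from compound 1 by having tert-butyl in place of phenyl on an aromatic carbon. Within the data shown here, no measured pair shows this change directly, and no step beyond the scatter is expected in this assay. The estimated 1.2-fold lower number from compound 1 to compound 4 (0.06 log units; within the scatter) is small. Compound 4 is expected at 5000 nM, with an estimated range of 1800 nM to 14000 nM.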

Compound 4, concentration for 50% growth inhibition: 1500 nM
Compound 4: middle estimate off by 3.3-fold (0.52 log units), on the high side, and the stated range ends above it.
By their numbers in this assay, from the lowest: compounds 3 and 4 (each within the scatter of the next); then compounds 1 and 2 (each within the scatter of the next).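

Replacing phenyl with tert-butyl on this aromatic carbon gives a 3.9-fold lower number from compound 1 to compound 4 (0.59 log units; beyond the scatter) in this assay, which means stronger inhibition of growth. So an aromatic ring is not needed at this position for inhibition, and a branched group with no ring and fewer heavy atoms does better here. Nothing available explains this gain. This single step cannot show whether losing the ring or the branched shape of tert-butyl matters more. Cyclohexyl, which keeps a non-aromatic ring, and isopropyl, a smaller branched group, remain open at this position.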